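This account rests on a few compounds, and the source may have more. Where it says the series, first, only, none or still open, it means among the compounds named here.

Measured so far in a functional assay on PC-3 cells (Homo sapiens) for cytotoxicity, read by MTT assay, with a stated time of 72 h; a higher number here means a weaker inhibitor of growth, a lower number a stronger inhibitor of growth:
compound 1 `C[Se]/C(=N\C(=O)c1cc2ccccc2s1)NC(=O)c1cc2ccccc2s1` — compound 1 gives 65600 nM
compound 2 `CS/C(=N\C(=O)c1cc2ccccc2s1)NC(=O)c1cc2ccccc2s1` — compound 2 gives 39400 nM

Compound 2 has the lowest of the two numbers in this assay; the step of a 1.7-fold lower number from compound 1 to compound 2 (0.22 log units; within the scatter) is within the scatter. Compound 3 `O=C(/N=C(/NC(=O)c1cc2ccccc2s1)[Se]Cc1ccccc1)c1cc2ccccc2s1` carries a group of 8 heavy atoms (7 carbon, 1 selenium; one six-membered aromatic ring of carbon only) in place of a group of 2 heavy atoms (1 carbon, 1 sulfur; no ring), on a carbon with a double bond to nitrogen. Within the data shown here, the only measured step that bears on this assay, a 1.7-fold lower number from compound 1 to compound 2 (0.22 log units; within the scatter), concerns the exchange of selenium for sulfur at the same position and lies within the scatter; nothing measured covers the larger group. The expected step of a 1.0-fold higher number from compound 2 to compound 3 (0.01 log units; within the scatter) is therefore none beyond the scatter. Compound 3 is estimated at 40000 nM, range 12000 nM to 130000 nM.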

Compound 3, concentration for total growth inhibition: 58400 nM
Compound 3: middle estimate off by 1.5-fold (0.16 log units), on the low side; low and high end bracket the measured number.
By their numbers in this assay, from the lowest: compounds 2, 3 and 1 (each within the scatter of the next).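

In this assay phenyl in place of hydrogen on the saturated chain carbon bound to a selenium atom gives a 1.1-fold lower number from compound 1 to compound 3 (0.05 log units; within the scatter) and so stays within the scatter. The larger exchange on the carbon with a double bond to nitrogen gives a 1.5-fold higher number from compound 2 to compound 3 (0.17 log units; within the scatter) and also stays within the scatter, so this position accepts a ring-bearing group without a readable change. No evidence on any cause is available.

Open, from the compounds shown here alone, is whether an amine, a carboxylic acid or a longer chain at this position would give a step beyond the scatter.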